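Series notes: a (4-bromophenyl)sulfonyl replacement on the core

The source may hold more compounds than are shown below. What is called first, only, known or untested is meant among the compounds shown, and "the series" means these compounds.

Measured so far:
compound 1 `N#CC1=C(NC(=S)Nc2ccccc2)N(c2ccc(S(N)(=O)=O)cc2)C2=C(C(=O)CCC2)C1c1ccc(Cl)cc1Cl` gives 95% in a functional assay on Ehrlich cells (Mus musculus) for cytotoxicity, read by trypan blue exclusion, with a stated time of 2 h, tested at 100 ug/mL; on this read-out higher numbers stand for a stronger effect at the one concentration tested and lower numbers for a weaker effect
compound 2 `N#CC1=C(NC(=S)Nc2ccc(Cl)cc2)N(c2ccc(S(N)(=O)=O)cc2)C2=C(C(=O)CCC2)C1c1ccc(Cl)cc1Cl` gives 100% in this assay

Compound 2 holds the higher of the two numbers, but the step of a number 5 percentage points higher from compound 1 to compound 2 (within the scatter) is within the scatter, so the two compounds cannot be told apart on this read-out. The unmeasured compound 3 `N#CC1=C(NS(=O)(=O)c2ccc(Br)cc2)N(c2ccc(S(N)(=O)=O)cc2)C2=C(C(=O)CCC2)C1c1ccc(Cl)cc1Cl` differs from compound 2 in one place: a group of 10 heavy atoms (6 carbon, 2 oxygen, 1 sulfur, 1 bromine; one six-membered aromatic ring of carbon only) in place of a group of 10 heavy atoms (7 carbon, 1 nitrogen, 1 sulfur, 1 chlorine; one six-membered aromatic ring of carbon only), on an amine nitrogen. Going by the values given here, no measured step resembles this change; the single step available, a number 5 percentage points higher from compound 1 to compound 2 (within the scatter), concerns a substituent on an aromatic carbon and bears on it only loosely. Both measured compounds sit near the top of the scale, so the expected step of a number 15 percentage points lower from compound 2 to compound 3 (beyond the scatter) is small to moderately downward, with wide uncertainty. For compound 3 the estimate in this assay is 85%, within 55% to 100%.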

Compound 3, a percentage reported as activity, at one concentration (the size of the read-out at that concentration, not a potency): 100%
The estimate for compound 3 lay 15 percentage points below the measured number; low and high end bracket the measured number.
By their numbers in this assay, from the lowest: compounds 1, 2 and 3 (each within the scatter of the next).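

On the amine nitrogen whose other neighbour is the double-bonded ring carbon, placing (4-bromophenyl)sulfonyl in this assay gives no change at the digits printed from compound 2 to compound 3 (within the scatter), and against the group of compound 1 it gives a number 5 percentage points higher from compound 1 to compound 3 (within the scatter). The earlier step concerned only a substituent on an aromatic carbon, whereas these steps show that the whole group on this nitrogen can be exchanged with the read-out remaining within the scatter. Nothing available accounts for this result.

All three compounds lie near the top of the scale at a single concentration, so this read-out leaves any difference among them unresolved. Also open, going by these compounds, is what a small group on this nitrogen, such as a free amine or an acetyl, would give, and whether a sulfonyl group with hydrogen in place of the bromine would read the same.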